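A few compounds are considered here, and "the series" means these few. Any claim that something is new, unique, unknown or untested is made for them only; others in the source may bear on it.

In a functional assay on MGC-803 cells (Homo sapiens) for cytotoxicity, read by MTT assay, with a stated time of 72 h (a lower number here means a stronger inhibitor, a higher number a weaker inhibitor), compound 1 `O=C1C(=Cc2ccc(O)cc2)C(=O)N(c2ccc(Cl)cc2)N1c1ccc(Cl)cc1` gives 19500 nM while compound 2 `O=C1C(=Cc2ccc(F)cc2)C(=O)N(c2ccc(Cl)cc2)N1c1ccc(Cl)cc1` gives 26000 nM and compound 3 `COc1cc(C=C2C(=O)N(c3ccc(Cl)cc3)N(c3ccc(Cl)cc3)C2=O)ccc1O` gives 21800 nM with the shared core unchanged. All three numbers lie within the scatter of one another, so compound 3 stands level with compound 1 and compound 2 and no ranking can be drawn. The change to compound 4 `COc1cccc(C=C2C(=O)N(c3ccc(Cl)cc3)N(c3ccc(Cl)cc3)C2=O)c1O` is 2-hydroxy-3-methoxyphenyl in place of 4-hydroxy-3-methoxyphenyl on a double-bonded chain carbon bound to a double-bonded ring carbon and it keeps the same atoms as compound 3, joined differently. Going by the values given here, three measured steps concern the same aromatic ring. They are a 1.3-fold higher number from compound 1 to compound 2 (0.12 log units; within the scatter) with fluoro in place of hydroxy, then a 1.1-fold higher number from compound 1 to compound 3 (0.05 log units; within the scatter) with methoxy in place of hydrogen, and a 1.2-fold lower number from compound 2 to compound 3 (0.08 log units; within the scatter) with 4-hydroxy-3-methoxyphenyl in place of 4-fluorophenyl. Each stays within the scatter, yet none of them shifts the hydroxy group to a new spot on the ring, so the data give no direct reading on this change. Compound 3 at 21800 nM is therefore the anchor, and no step beyond the scatter is expected in this assay with no direction favoured. The estimated move is a 1.1-fold lower number from compound 3 to compound 4 (0.04 log units; within the scatter) and so is expected to stay small. Compound 4 is estimated at 20000 nM with an expected range from 9000 nM to 42000 nM for repeat measurements.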

Compound 4, half-maximal inhibitory concentration: 24300 nM
Estimate against measurement, compound 4: 1.2-fold (0.08 log units) below; the range from low to high includes it.
By their numbers in this assay, from the lowest: compounds 1, 3, 4 and 2 (each within the scatter of the next).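

In this assay, going by these compounds alone, the hydroxy group moves for the first time, with 2-hydroxy-3-methoxyphenyl in place of 4-hydroxy-3-methoxyphenyl, and the result is a 1.1-fold higher number from compound 3 to compound 4 (0.05 log units; within the scatter) and so no detectable effect of this change on the number. Compound 4 also sits level with the other two compounds, as a 1.1-fold lower number from compound 2 to compound 4 (0.03 log units; within the scatter) and a 1.2-fold higher number from compound 1 to compound 4 (0.10 log units; within the scatter) both show, so all four compounds now stand within the scatter of one another and no ranking among these ring patterns can be drawn. No measurement is available that would explain why this swap leaves the number level.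

The groups on this aromatic ring so far are only hydroxy, methoxy and fluoro, so these four compounds cannot tell whether a quite different group there, such as an amine or a carboxylic acid, would produce a step beyond the scatter. Every compound also carries the same shared core, which leaves open whether a change to the core itself would matter more than any change on this ring.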